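This account rests on a few compounds, and the source may have more. Where it says the series, first, only, none or still open, it means among the compounds named here.

Measured so far:
compound 1, `N#Cc1cnc(NCc2cnccc2C(F)(F)F)cc1NC[C@H]1CC[C@H](O)CC1`, gives 50 nM in an assay on isolated protein for inhibition of protein kinase C theta type (Homo sapiens), read by TR-FRET, with a stated time of 2 h; on this read-out lower numbers stand for stronger inhibition and higher numbers for weaker inhibition
compound 2, `CC1(C)C[C@H](Nc2cc(NCc3cnccc3C(F)(F)F)ncc2C#N)CC[C@H]1O`, gives 100 nM in this assay

Among the compounds with values here, compound 2 stands at the higher of the two numbers so far, and its only neighbour is compound 1; the step between them, a 2.0-fold higher number from compound 1 to compound 2 (0.30 log units; within the scatter), lies within the scatter, so no order is claimed between these two.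

Compound 3, `CC1(C)[C@@H](Nc2cc(NCc3cnccc3C(F)(F)F)ncc2C#N)C[C@@H]1C(N)=O`, differs from compound 2 by 3-carbamoyl-2,2-dimethylcyclobutyl in place of 4-hydroxy-3,3-dimethylcyclohexyl on a nitrogen on an aromatic ring. Within the data shown here, the single measured step bears on it only loosely: it exchanged one hydroxy-bearing saturated ring for another at the same nitrogen and moved the number by no more than the scatter. Among the measured compounds shown here, the change to compound 3 goes further, since the six-membered ring becomes a four-membered one and the hydroxyl gives way to a carbamoyl group, and no measured pair covers either part of that. A step of modest size in this assay is therefore expected, most likely toward a higher number, with a wide range; compound 3 is estimated to give 200 nM, between 50 nM and 800 nM. That estimate means a step of a 2.0-fold higher number from compound 2 to compound 3 (0.30 log units; within the scatter), expected rather than known.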

Compound 3, half-maximal inhibitory concentration: 1100 nM
The estimate for compound 3 lay 5.5-fold (0.74 log units) below the measured number; the whole stated range lies below it.
By their numbers in this assay, from the lowest: compounds 1 and 2 (each within the scatter of the next); then compound 3.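

At the nitrogen on an aromatic ring, the position no longer looks tolerant of any substituent: the exchange of one hydroxy-bearing saturated ring for another had stayed within the scatter, whereas 3-carbamoyl-2,2-dimethylcyclobutyl in place of 4-hydroxy-3,3-dimethylcyclohexyl gives an 11-fold higher number from compound 2 to compound 3 (1.04 log units; beyond the scatter) in this assay. The same group in place of (4-hydroxycyclohexyl)methyl gives a 22-fold higher number from compound 1 to compound 3 (1.34 log units; beyond the scatter), so the loss appears against both hydroxy-bearing comparators. Heavy-atom, donor and acceptor counts are the same for the two groups exchanged in the step to compound 3, so these counts do not distinguish them, while the ring size and the hydroxyl-to-carbamoyl exchange change together.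

Nothing available explains the size of either step. Still open, going by these compounds, is whether the four-membered ring or the carbamoyl group carries the loss, a question that a hydroxyl on the 2,2-dimethylcyclobutyl ring or a carbamoyl on the 3,3-dimethylcyclohexyl ring would address, and whether an amine or a carboxylic acid in place of the carbamoyl would behave differently.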